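Chloro for hydrogen on a cytotoxicity ceiling

A few compounds are considered here, and "the series" means these few. Any claim that something is new, unique, unknown or untested is made for them only; others in the source may bear on it.

Measured so far in an ADME assay on Vero cells (Chlorocebus sabaeus) for cytotoxicity, read by MTT assay, with a stated time of 96 h; on this read-out lower numbers stand for higher toxicity in this test and higher numbers for lower toxicity in this test:
- compound 1 `CC(=O)c1ccc2[nH]c(-c3ccccc3)nc2c1` gives > 100000 nM, a limit of the assay rather than a number.
- compound 2 `CC(=O)c1ccc2[nH]c(-c3ccc(Cl)cc3)nc2c1` gives > 100000 nM, likewise a limit.
- compound 3 `C/C(=N\NC(N)=O)c1ccc2c(c1)nc(-c1ccccc1)n2C1CCCCC1` gives > 100000 nM, again only a limit.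

All three values sit at the limit of > 100000 nM in this assay, at which 3 of the 3 values shown sit. Among the measured compounds shown here, the one change that is shared, (chloro in place of hydrogen on an aromatic carbon), gives the step that the two limits leave unreadable from compound 1 to compound 2 in this assay; with both ends at the limit, its size cannot be read. Compound 4 `C/C(=N\NC(N)=O)c1ccc2c(c1)nc(-c1ccc(Cl)cc1)n2C1CCCCC1` carries the same change on the core of compound 3, (chloro in place of hydrogen on an aromatic carbon); the place described is the same word for word as from compound 1 to compound 2. The difference between the core of compound 1 and that of compound 3 is not broken down here.

With compounds 1, 2 and 3 all at the limit, and no readable step to rest on, compound 4 is expected to stay at the limit as well, so the estimated step that the limit leaves unreadable from compound 3 to compound 4 in this assay is close to none. For compound 4 the estimate in this assay is 150000 nM, expected between 50000 nM and 500000 nM, most likely reported only as a limit.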

Compound 4, half-maximal cytotoxic concentration: > 100000 nM
Compound 4: only a limit was reported (the forecaster's own chance of this, stated with the estimate: 85%); the middle value does not contradict the limit.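

Compound 3 and compound 4 give no readable step in this assay, both values being limits of the assay: the limit of > 100000 nM in this assay, at which 4 of the 4 values shown sit.

The compounds shown leave open how large the phenyl to 4-chlorophenyl change is on either core, and at what concentration, if any, cytotoxicity would appear.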